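A few compounds are considered here, and "the series" means these few. Any claim that something is new, unique, unknown or untested is made for them only; others in the source may bear on it.

Measured in a functional assay on the whole organism (stomach) with Canis familiaris (Canis lupus familiaris) as the target; a higher number here means that more compound is needed for the effect, a lower number that less compound is needed:
- Compound 1 `COC(=O)CC/C=C\CC[C@H]1C(=O)C[C@@H](O)[C@@H]1/C=C/C[C@@](C)(O)/C=C/C1CCCC1`: 0.0003 mg/kg
- Compound 2 `COC(=O)CC/C=C\CC[C@H]1C(=O)C[C@@H](O)[C@@H]1/C=C/C[C@@](C)(O)/C=C/C1(C)CC1`: 0.00002 mg/kg

Within the data shown here, compound 2 holds the lower of these two numbers, and the gap to its only neighbour lies beyond the scatter. Compound 3 `COC(=O)CC/C=C\CC[C@H]1C(=O)C[C@@H](O)[C@@H]1/C=C/C[C@@](C)(O)/C=C/C1CCC1` has not yet been measured. It shares its core with compound 2 and differs in one group: cyclobutyl in place of 1-methylcyclopropyl on a double-bonded chain carbon bound to a double-bonded chain carbon. Among the measured compounds shown here, only one measured step bears on this change, a 15-fold lower number from compound 1 to compound 2 (1.18 log units; beyond the scatter). That step also arrives at the 1-methylcyclopropyl group, but it starts from cyclopentyl, not cyclobutyl. For the measured compounds named here, no compound with a cyclobutyl group has a measured value, so the evidence is thin. Compound 3 carries a ring without the methyl group, as compound 1 does with its cyclopentyl, and compound 1 stands at 0.0003 mg/kg. A move back towards a higher number in this assay is therefore expected, covering part of the size of the measured step. The expected change is a 5.0-fold higher number from compound 2 to compound 3 (0.70 log units; beyond the scatter). For compound 3 the estimated value is 0.0001 mg/kg, with an expected range from 0.00002 mg/kg to 0.0005 mg/kg.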

Compound 3, dose for half-maximal effect: 0.00005 mg/kg
Compound 3: middle estimate off by 2.0-fold (0.30 log units), on the high side; low and high end bracket the measured number.
By their numbers in this assay, from the lowest: compound 2; then compound 3; then compound 1.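

In this assay, 1-methylcyclopropyl and cyclobutyl have the same atoms joined differently, yet the change at this place on a double-bonded chain carbon bound to a double-bonded chain carbon gives a 2.5-fold higher number from compound 2 to compound 3 (0.40 log units; beyond the scatter), so the rearrangement alone moves the number beyond the scatter. Among the rings without a methyl group, the replacement of cyclopentyl by cyclobutyl gives a 6.0-fold lower number from compound 1 to compound 3 (0.78 log units; beyond the scatter), which shows that the number also changes when no methyl group is involved; for these three compounds, the order from the lowest number runs 1-methylcyclopropyl, cyclobutyl, cyclopentyl. Nothing given here accounts for this order.

The compounds shown do not separate the effect of ring size from that of the methyl group, and how a plain cyclopropyl or a 1-methylcyclobutyl would stand in this assay remains open. Also open, as far as these compounds go, is whether the ring itself is needed at this place, as an open-chain group such as tert-butyl would show, and whether the order would hold for a larger ring such as cyclohexyl.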